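Toxicity notes on the benzoyl pyridinone ester series

A few compounds are considered here, and "the series" means these few. Any claim that something is new, unique, unknown or untested is made for them only; others in the source may bear on it.

Compound 1 `CCOC(=O)c1[nH]c(=O)c(C#N)cc1C(=O)c1ccc(C)cc1`, this assay an ADME assay on J774.A1 cells (Mus musculus) for cytotoxicity, read by MTT assay, with a stated time of 48 h; on this read-out higher numbers stand for lower toxicity in this test and lower numbers for higher toxicity in this test: 194000 nM
Compound 2 `CCOC(=O)c1[nH]c(=O)c(C#N)cc1C(=O)c1ccc([N+](=O)[O-])cc1`, this assay: only a limit, < 100000 nM

Compound 1 gives a measured value in this assay. For compound 2 the assay reports only a limit, so no number for it is known. Among the compounds with values here, the one measured step, an at least 1.9-fold lower number from compound 1 to compound 2 (0.28 log units; that floor lies within the scatter), is thus bounded by the limit of < 100000 nM in this assay, at which 1 of the 2 values shown sits, and its true size is open; the floor of that step itself lies within the scatter.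

Compound 3 `CCOC(=O)c1[nH]c(=O)c(C#N)cc1C(=O)c1ccc(Br)cc1` carries bromo in place of nitro on an aromatic carbon. Within the data shown here, no measured step exchanges bromo for any other group, so the only bearing comes from the step from compound 1 to compound 2, which reads as a move toward higher toxicity of unknown extent. With compound 2 itself known only as a limit, the size and direction of the step to compound 3 cannot be anchored; a change beyond the scatter in either direction is possible, and none is firmly expected.

For compound 3 the expected result in this assay is 120000 nM, within a range of 50000 nM to 250000 nM, which corresponds to an estimated step of an at least 1.2-fold higher number from compound 2 to compound 3 (0.07 log units; that floor lies within the scatter).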

Compound 3, half-maximal cytotoxic concentration: < 100000 nM
Compound 3 gave a limit, no number; the forecaster's own chance of this, stated with the estimate: 40%; at least 1.2-fold (0.07 log units) between middle value and limit.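

With bromo on the aromatic carbon para to a large group, compound 3 gives < 100000 nM in this assay as a limit and not a number. Set against methyl, this change reads as an at least 1.9-fold lower number from compound 1 to compound 3 (0.28 log units; that floor lies within the scatter) and so a second group at this place, besides nitro, gives a step of open size whose floor stays inside the scatter. The step between nitro and bromo cannot be read, and this position now holds two different groups that end at the same limit, with only methyl giving a number: the limit of < 100000 nM in this assay, at which 2 of the 3 values shown sit.

Still open, going by these compounds, are the true values of compound 2 and compound 3, how they stand to each other, and whether either truly departs from compound 1 by more than the scatter. Also open, on these data alone, is how an amine, a carboxylic acid or a longer chain at this position would read on the shared core, and whether any such group would return a number rather than a limit.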